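This account rests on a few compounds, and the source may have more. Where it says the series, first, only, none or still open, it means among the compounds named here.

For the measured compounds named here, compound 3 `COc1cc2c(Oc3ccc(NC(=O)c4nn(-c5ccccc5)c(=O)c5ccccc45)cc3F)ccnc2cc1OCCCN1CCN(C)CC1` gives 1580 nM in a functional assay on MDA-MB-231 cells (Homo sapiens) for cytotoxicity, read by MTT assay, with a stated time of 72 h (on this read-out lower numbers stand for stronger inhibition and higher numbers for weaker inhibition), and stands second highest of the three numbers measured so far. Compound 1 `COc1cc2c(Oc3ccc(NC(=O)c4nn(-c5ccccc5)c(=O)c5ccccc45)cc3F)ccnc2cc1OCCCN1CCCC1` gives 1130 nM, the gap a 1.4-fold higher number from compound 1 to compound 3 (0.15 log units; within the scatter) falling within the scatter, while compound 2 `COc1ccc(-n2nc(C(=O)Nc3ccc(Oc4ccnc5cc(OCCCN6CCCC6)c(OC)cc45)c(F)c3)c3ccccc3c2=O)cc1` gives 3450 nM. Compound 4 `COc1cc2c(Oc3ccc(NC(=O)c4nn(-c5ccc(Br)cc5)c(=O)c5ccccc45)cc3F)ccnc2cc1OCCCN1CCN(C)CC1` differs from compound 3 by bromo in place of hydrogen on an aromatic carbon. Going by the values given here, no measured step involves a halogen; the only change on the same phenyl ring is a 3.1-fold higher number from compound 1 to compound 2 (0.48 log units; beyond the scatter), with methoxy rather than bromo entering, so it bears on the present step only loosely. A modest weakening is therefore expected, a 1.6-fold higher number from compound 3 to compound 4 (0.20 log units; within the scatter), though a result within the scatter would not be surprising. Compound 4 is estimated at 2500 nM, with a range from 900 nM to 7000 nM.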

Compound 4, half-maximal inhibitory concentration: 1370 nM
The estimate for compound 4 lay 1.8-fold (0.26 log units) above the measured number, within the range that was stated.
By their numbers in this assay, from the lowest: compounds 1, 4 and 3 (each within the scatter of the next); then compound 2.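

The phenyl to 4-bromophenyl change in this assay gives a 1.2-fold lower number from compound 3 to compound 4 (0.06 log units; within the scatter) and so shows that this ring position takes a bromine with no step beyond the scatter. The methoxy change on the same ring gives a 3.1-fold higher number from compound 1 to compound 2 (0.48 log units; beyond the scatter) but was read with pyrrolidin-1-yl in place of 4-methylpiperazin-1-yl, so the two steps do not share a background. Nothing available explains the bromo result. Open, as far as these compounds go, are whether fluoro, chloro or a nitrile at this position would behave like bromo, and whether bromo would give the same result with pyrrolidin-1-yl.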